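Loss of the methyl on a ring amine nitrogen

The source may hold more compounds than are shown below. What is called first, only, known or untested is meant among the compounds shown, and "the series" means these compounds.

In an ADME assay on the whole organism (strain Sprague-Dawley) for metabolic stability, with Rattus norvegicus as the target (on this read-out lower numbers stand for a shorter-lived compound and higher numbers for a longer-lived compound), compound 2 (`CN1CCCC1c1ccc(N2CC[C@H](NS(=O)(=O)/C=C/c3ccc(Cl)s3)C2=O)c(F)c1`) gives 1.4 h as the lower of two numbers, while compound 1 (`CN(C)[C@H]1CCc2cc(N3CC[C@H](NS(=O)(=O)c4ccc5cc(Cl)ccc5c4)C3=O)ccc21`) gives 4.4 h and the gap lies beyond the scatter. Compound 3 (`O=C1[C@@H](NS(=O)(=O)/C=C/c2ccc(Cl)s2)CCN1c1ccc(C2CCCN2)cc1F`) carries hydrogen in place of methyl on an amine nitrogen in a ring. Among the measured compounds shown here, no measured pair shows this change, so no step beyond the scatter is expected in this assay in either direction. The estimated step of a 1.1-fold higher number from compound 2 to compound 3 (0.03 log units; within the scatter) stays within the scatter. The expected half-life of compound 3 is 1.5 h with an estimated range (0.7 h to 3.2 h).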

Compound 3, half-life: 3.4 h
Estimate against measurement, compound 3: 2.3-fold (0.36 log units) below; measured number outside the range, above it.
By their numbers in this assay, from the lowest: compound 2; then compounds 3 and 1 (each within the scatter of the next).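

In this assay, among the compounds shown here, hydrogen in place of methyl on the amine nitrogen of the five-membered ring gives the first single-place step (a 2.4-fold higher number from compound 2 to compound 3 (0.39 log units; beyond the scatter)). This position therefore affects half-life, and 1-methylpyrrolidin-2-yl to pyrrolidin-2-yl is the direction that gives the higher number. Nothing at hand bears on what lies behind this step.

From the compounds shown here alone, it remains open whether an ethyl or acetyl group on this nitrogen would give a number on either side of compound 3. One pair also cannot show whether the step carries over to another core.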